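This account rests on a few compounds, and the source may have more. Where it says the series, first, only, none or still open, it means among the compounds named here.

Measured so far:
- Compound 1 `COc1cc(-c2nccn2-c2ccc(F)cc2)cc(OC)c1OC`: 68600 nM
- Compound 2 `COc1ccc(NC(=O)c2cc(OC)c(OC)c(OC)c2)cc1[N+](=O)[O-]`: 17600 nM

These two values come from a functional assay on HCT-15 cells (Homo sapiens) for antiproliferative activity, read by MTT assay, with a stated time of 72 h; on this read-out higher numbers stand for weaker inhibition and lower numbers for stronger inhibition. Compound 2, at 17600 nM, holds the lower of the two numbers, and its gap to compound 1 lies beyond the usual scatter. Both compounds are weak inhibitors in this assay.

The next compound, compound 3 `COc1ccc(NC(=O)c2cc(OC)c(OC)c(OC)c2)cc1N`, is compound 2 with amino in place of nitro on an aromatic carbon, ortho to a methoxy group: amino in place of nitro on an aromatic carbon. Going by the values given here, no measured pair shows this exchange, so the data offer no direct precedent for its size. The expected change, a 1.6-fold lower number from compound 2 to compound 3 (0.20 log units; within the scatter), is a modest one leaning towards stronger inhibition, and no step beyond the scatter is expected. The estimate for compound 3 is 11000 nM, with an expected range of 3000 nM to 40000 nM.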

Compound 3, half-maximal inhibitory concentration: 6500 nM
Compound 3: middle estimate off by 1.7-fold (0.23 log units), on the high side; measured number inside the range.
By their numbers in this assay, from the lowest: compound 3; then compound 2; then compound 1.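

In this assay, putting amino in place of nitro on this aromatic carbon, ortho to a methoxy group, gives a 2.7-fold lower number from compound 2 to compound 3 (0.43 log units; beyond the scatter). Going by these compounds alone, this is the first measured sign that the position responds to a change of group, and the step, though modest, lies beyond the usual scatter. Its direction is towards stronger inhibition, with the rest of the structure unchanged, so the difference in this pair rests on this one exchange alone. Nothing in the data explains why the number falls with this exchange. The compounds shown leave open how an acetamide, a dimethylamino group or a hydroxyl group on the same carbon would compare with amino, and whether the same exchange of nitro for amino would give a similar step at another carbon of this ring.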